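Adding a Fluoro Group to a Short-Lived Compound

This account rests on a few compounds, and the source may have more. Where it says the series, first, only, none or still open, it means among the compounds named here.

Measured compounds:
compound 1 `Cc1cccc2c(-c3ccc4ccc(Cl)cc4n3)c[nH]c12`: 1.48 h
compound 2 `Fc1ccc2c(-c3ccc4ccccc4n3)c[nH]c2c1F`: 0.167 h
compound 3 `Fc1ccc2c(-c3ccc4ccccc4n3)c[nH]c2c1Cl`: 0.183 h

In an ADME assay on microsomes from liver (Homo sapiens) for metabolic stability, using NADPH, with a stated time of 40 min, tested at 2 uM (on this read-out lower numbers stand for a shorter-lived compound and higher numbers for a longer-lived compound), compound 2 gives the lowest of the three numbers. Its nearest neighbour is compound 3, reached by a 1.1-fold higher number from compound 2 to compound 3 (0.04 log units; within the scatter). Compound 1 stands far higher, beyond the scatter.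

Compound 4 `Fc1cc2c(-c3ccc4ccccc4n3)c[nH]c2c(F)c1F` differs from compound 2 by one change: fluoro in place of hydrogen on an aromatic carbon.

Among the compounds with values here, no measured pair shows fluoro in place of hydrogen. Within the data shown here, the only single-point step, from compound 2 to compound 3, swaps one halogen for another and lies within the scatter. With nothing pointing otherwise, no step beyond the scatter is expected in this assay for compound 4; its value is estimated at 0.2 h (0.1 h to 0.4 h), a step of a 1.2-fold higher number from compound 2 to compound 4 (0.08 log units; within the scatter).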

Compound 4, half-life: 0.25 h
Estimate against measurement, compound 4: 1.3-fold (0.10 log units) below, and the stated range covers the measured number.
By their numbers in this assay, from the lowest: compounds 2, 3 and 4 (each within the scatter of the next); then compound 1.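

In this assay, fluoro in place of hydrogen on this aromatic carbon, ortho to a fluoro group, gives a 1.5-fold higher number from compound 2 to compound 4 (0.18 log units; within the scatter). The earlier compounds shown here showed only one halogen swapped for another, whereas this step shows that a halogen can be added at a new position on the ring without a change beyond the scatter. Nothing measured here explains this result. Going by these compounds, whether a methoxy group, an amine or a nitrile on this same carbon would move the half-life beyond the scatter remains open. So does whether fluoro here would behave the same way on the core of compound 1.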